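Trading a silyl group for an amide on the ring of compound 2

The compounds below may be only part of what the source reports. "The series", "measured", "known", "first", "only" and "open" are said of these compounds alone.

Compound 2 `CC[Si](CC)(CC)C/C1=C/C[C@](C)(CCC=C(C)C)/C=C/[C@@H](OC(=O)C=C(C)C)[C@](C)(O)/C=C/C1=O` gives 2810 nM in a functional assay on HL-60 cells (Homo sapiens) for antiproliferative activity, read by MTT assay, with a stated time of 48 h (on this read-out lower numbers stand for stronger inhibition and higher numbers for weaker inhibition), the highest of the two numbers measured, while compound 1 `CC(=O)O[C@]1(C)/C=C/C(=O)/C(CO)=C\C[C@](C)(CCC=C(C)C)/C=C/[C@H]1OC(=O)C=C(C)C` gives 2370 nM, a gap within the scatter. Compound 3 `CC(C)=CCC[C@]1(C)/C=C/[C@@H](OC(=O)C=C(C)C)[C@](C)(O)/C=C/C(=O)/C(C(=O)N(C(C)C)C(C)C)=C\C1` differs from compound 2 by a group of 9 heavy atoms (7 carbon, 1 nitrogen, 1 oxygen; no ring) in place of a group of 8 heavy atoms (7 carbon, 1 silicon; no ring), on a double-bonded ring carbon. Going by the values given here, no measured pair shows what such a change does, so the step from compound 2 to compound 3 is expected to stay within the scatter, with no clear direction. Compound 3 is therefore estimated to give 3000 nM in this assay, between 1000 nM and 9000 nM, a step of a 1.1-fold higher number from compound 2 to compound 3 (0.03 log units; within the scatter).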

Compound 3, half-maximal inhibitory concentration: 12700 nM
Beside the measured number, compound 3's estimate is 4.2-fold (0.63 log units) below it; the whole stated range lies below it.
By their numbers in this assay, from the lowest: compounds 1 and 2 (each within the scatter of the next); then compound 3.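

In this assay the exchange of the silicon-bearing group for diisopropylcarbamoyl on the double-bonded ring carbon gives a 4.5-fold higher number from compound 2 to compound 3 (0.66 log units; beyond the scatter) and so shows that inhibition responds to what this ring carbon carries. Here the amide goes with weaker inhibition than the silyl group, a modest loss rather than an abolition of activity. The data at hand give no reason for this step. Going by these compounds, whether a smaller amide such as dimethylcarbamoyl, or a carboxylic acid, on this carbon would fare differently stays open, and one pair cannot show which part of the diisopropylcarbamoyl group matters.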